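Geometry of the acid double bond in a retinoid series

The source may hold more compounds than are shown below. What is called first, only, known or untested is meant among the compounds shown, and "the series" means these compounds.

Compound 1 `CC1(C)CCC(C)(C)c2cc(C(=O)c3ccc(/C=C/C(=O)O)cc3)ccc21`: 78%
Compound 2 `Cc1cc(C(=O)c2ccc3c(c2)C(C)(C)CCC3(C)C)ccc1/C=C/C(=O)O`: 66%

In a functional assay for activation of retinoic acid receptor beta (Homo sapiens) (on this read-out lower numbers stand for smaller maximal responses and higher numbers for larger maximal responses), compound 1 stands highest of the two numbers; its nearest neighbour is compound 2, reached by a number 12 percentage points lower from compound 1 to compound 2 (beyond the scatter). Compound 3 `CC1(C)CCC(C)(C)c2cc(C(=O)c3ccc(/C=C\C(=O)O)cc3)ccc21` differs from compound 1 in one respect: the two compounds have the same atoms and bonds and differ only in configuration as drawn: 1 of 1 stereo elements differ; a double bond is drawn E in compound 1 and Z in compound 3. Going by the values given here, the single measured step concerns a methyl on an aromatic carbon and does not bear on a change of double-bond geometry, so no step informs this change directly. Compound 3 is therefore estimated at 50% in this assay, with a range from 20% to 80%, which would be an expected step of a number 28 percentage points lower from compound 1 to compound 3 (beyond the scatter).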

Compound 3, largest response reached (reported as maximum), in percent of the reference or control that the assay uses: 41%
Compound 3: the middle estimate sits 9 percentage points above what was measured; the range from low to high includes it.
By their numbers in this assay, from the lowest: compound 3; then compound 2; then compound 1.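

Changing only the geometry of the double bond that carries the acid, from E to Z, gives in this assay a number 37 percentage points lower from compound 1 to compound 3 (beyond the scatter). With compound 3 still at 41%, the Z geometry lowers the maximal response without abolishing it. The step can be assigned to this geometry alone because nothing else separates the pair, as shown by this: the fact that compounds 1 and 3 differ only in the configuration as drawn

As far as these compounds go, whether the same change would cost as much in the methyl-bearing compound 2 remains open. So does the effect of a primary amide or a tetrazole in place of the carboxylic acid.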